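Swapping the aniline ring of a diaryl urea

The source may report more compounds than this note shows. Statements on the series, on what has been measured and on what is new or still open speak of the compounds shown alone.

Measured compounds:
compound 1, `Cc1ccc(Nc2cc(NC(=O)Nc3c(Cl)cccc3Cl)ncn2)cc1F`, 45.3%
compound 2, `COc1cc(NC(=O)Nc2cc(Nc3ccc(F)c(Cl)c3)ncn2)cc(OC)c1`, 53%

The two measured compounds share a core that carries a urea on one side and an aryl amine on the other. In a functional assay on NCI-H1581 cells (Homo sapiens) for inhibition, read by MTT assay, with a stated time of 48 h, tested at 10 uM (on this read-out higher numbers stand for more inhibition at the one concentration tested (going by the name of the read-out) and lower numbers for less inhibition), compound 1 gives 45.3%, the lower of the two numbers, while compound 2 gives 53%; the two values lie within the scatter of each other, so nothing separates them.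

Compound 3, `O=C(Nc1cc(Nc2ccc(F)c(Cl)c2)ncn1)Nc1c(Cl)cccc1Cl`, has not been tested. It differs from compound 1 in one place: 3-chloro-4-fluorophenyl in place of 3-fluoro-4-methylphenyl on a nitrogen on an aromatic ring. For the measured compounds named here, the new ring is the same one that compound 2 carries on its amine nitrogen, though compound 2 also has a different urea end, so no single step links it to compound 3. Going by the values given here, with only two values at hand and both close together, the step from compound 1 to compound 3 is expected to stay within the scatter, with no clear direction: a number 2.7 percentage points higher from compound 1 to compound 3 (within the scatter). Compound 3 is therefore expected to give about 48%, in a range from 32% to 64%.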

Compound 3, a percentage reported as inhibition, at one concentration (the size of the read-out at that concentration, not a potency): 67%
Estimate against measurement, compound 3: 19 percentage points below; measured number above the stated range.
By their numbers in this assay, from the lowest: compounds 1 and 2 (each within the scatter of the next); then compound 3.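

In this assay the aryl group on the amine nitrogen proves able to move the read-out: a number 21.7 percentage points higher from compound 1 to compound 3 (beyond the scatter), a step beyond the scatter, with the rest of the molecule unchanged. For the compounds shown here, compound 1 and compound 2 differ in more than one place, so their close values could say nothing about this position alone, whereas the single change from 3-fluoro-4-methylphenyl to 3-chloro-4-fluorophenyl on a nitrogen on an aromatic ring isolates it, and the two groups match in every count given for them, including heavy atoms and hydrogen-bond donors and acceptors. Nothing at hand accounts for why this swap gives a step of this size.

The compounds shown leave open which part of the swap carries the step, as the 3-fluoro and 4-methyl groups of compound 1 are both replaced at once by the 3-chloro and 4-fluoro groups of compound 3, so the two substituent changes cannot be told apart. Also open, from the compounds shown here alone, are how the same swap behaves with the urea end of compound 2 and how a ring bearing an amine or a carboxylic acid would read at this nitrogen.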